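The source may report more compounds than this note shows. Statements on the series, on what has been measured and on what is new or still open speak of the compounds shown alone.

Of the compounds shown here, two of the shared core have been measured in a functional assay on 786-0 cells (Homo sapiens) for inhibition, read by sulforhodamine B assay, with a stated time of 48 h, tested at 10 uM; on this read-out lower numbers stand for less inhibition and higher numbers for more inhibition at the one concentration tested (going by the name of the read-out). Compound 1 `c1ccc(-c2cn3ccnc3c(-c3ccc4ncn(C5CCCCC5)c4c3)n2)cc1` gives 36.8% in this assay. Compound 2 `CCc1ccc(-c2cn3ccnc3c(-c3ccc4ncn(Cc5ccccc5)c4c3)n2)cc1` gives 38.1% in this assay, a number within the scatter of that of compound 1, so the two cannot be told apart on the numbers shown. Compound 3 `Cc1cccc(-c2cn3ccnc3c(-c3ccc4ncn(Cc5ccccc5)c4c3)n2)c1` is the next compound of the series and has not yet been measured in this assay. It differs from compound 2 in one place: 3-methylphenyl in place of 4-ethylphenyl on an aromatic carbon. Among the compounds with values here, no step between measured compounds bears on this change, and compound 1 differs from compound 2 in another place, so its value gives no guide to the size of the step. With no shown step to rest on, the step from compound 2 to compound 3 is expected to be none beyond the scatter, a number 1.1 percentage points lower from compound 2 to compound 3 (within the scatter). Compound 3 is therefore estimated at 37% in this assay, within 20% to 55%.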

Compound 3, a percentage reported as inhibition, at one concentration (the size of the read-out at that concentration, not a potency): 21.5%
Compound 3: the middle estimate sits 15.5 percentage points above what was measured; measured number inside the range.
By their numbers in this assay, from the lowest: compound 3; then compounds 1 and 2 (each within the scatter of the next).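

In this assay, 3-methylphenyl in place of 4-ethylphenyl on this aromatic carbon gives a number 16.6 percentage points lower from compound 2 to compound 3 (beyond the scatter). Within the data shown here, this is the first step that can be read at this position, and it shows that the aryl group here can change the read-out; however, the change shortens the alkyl group and moves it around the phenyl ring at once, so this one step cannot separate the two. Nothing at hand bears on the reason for this step.

Going by these compounds, whether chain length or placement on the phenyl ring carries the step remains open, and 4-methylphenyl or 3-ethylphenyl at this position would bear directly on that question. Also open, on these data alone, is how an amine or a carboxylic acid on this phenyl ring would read in this assay.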